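A Fluorophenylamino Variant of Compound 1 in Paw Edema

This account rests on a few compounds, and the source may have more. Where it says the series, first, only, none or still open, it means among the compounds named here.

For the measured compounds named here, compound 1 `c1ccc(-c2ccc(OCc3nnc(-c4ccccc4)o3)cc2)cc1` is one of three compounds measured in a functional assay on the whole organism (strain Wistar) for inhibition, with Rattus norvegicus as the target, read by paw edema, with a stated time of 3 h, at a dose of 10 mg/kg by the oral route (on this read-out higher numbers stand for more inhibition at the one dose given (going by the name of the read-out) and lower numbers for less inhibition), where compound 1 gives 18.2%. Compound 3 `COc1ccc2cc(C(C)c3nnc(COc4ccc(-c5ccccc5)cc4)o3)ccc2c1` gives 25% in this assay, which lies within the scatter of the number for compound 1. Going by the values given here, compound 2 `Clc1ccccc1-c1nnc(COc2ccc(-c3ccccc3)cc2)o1` gives 59.1%, and the step of a number 40.9 percentage points higher from compound 1 to compound 2 (beyond the scatter) is the only single-point change measured so far; it came from chloro in place of hydrogen on an aromatic carbon.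

Compound 4 `Fc1ccc(Nc2nnc(COc3ccc(-c4ccccc4)cc3)o2)cc1` differs from compound 1 at another site: (4-fluorophenyl)amino in place of phenyl on an aromatic carbon. Among the compounds with values here, no measured step bears directly on this change; the step from compound 1 to compound 2 concerns a different position and a different kind of group, so it can only show that a single change at the core of compound 1 is able to move this assay by a large amount. The numbers for compound 1 and compound 3 show that two rather different groups at this position leave the read-out within the scatter of each other.

Compound 4 is therefore expected to land near 30%, with a range from 12% to 55%, the estimated step being a number 11.8 percentage points higher from compound 1 to compound 4 (beyond the scatter).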

Compound 4, a percentage reported as inhibition, in the whole organism at one dose (the size of the read-out at that dose, not a potency): 52.3%
Compound 4: middle estimate off by 22.3 percentage points, on the low side; the range from low to high includes it.
By their numbers in this assay, from the lowest: compounds 1 and 3 (each within the scatter of the next); then compounds 4 and 2 (each within the scatter of the next).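

In this assay, the step of a number 34.1 percentage points higher from compound 1 to compound 4 (beyond the scatter) shows that the carbon of the five-membered ring bearing phenyl in compound 1 can give a large rise with a second kind of group, not only with the 2-chlorophenyl of compound 2, although this does not hold for every group there, as compound 3 gives 25%, within the scatter of compound 1. The (4-fluorophenyl)amino group brings a nitrogen link and a hydrogen-bond donor that 2-chlorophenyl lacks, yet the step of a number 6.8 percentage points lower from compound 2 to compound 4 (within the scatter) leaves the two groups indistinguishable in this read-out. No measured evidence explains why either group gives a higher number than phenyl.

The compounds shown leave open whether the amine link or the fluorine carries the step from phenyl, a question that a plain phenylamino group and a 4-fluorophenyl group set directly on the ring could separate. They also leave open how a group without an aromatic ring, such as morpholine or a short alkyl chain, would read at this place.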